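The source may report more compounds than this note shows. Statements on the series, on what has been measured and on what is new or still open speak of the compounds shown alone.

Measured so far:
compound 1, `COc1cccc(C(=O)/C=C/c2ccccc2)c1`: 14800 nM
compound 2, `O=C(/C=C/c1ccccc1)c1ccccc1C(F)(F)F`: 8500 nM

Both compounds share the same core and differ only in the group carried on the aromatic ring attached to the carbonyl. In an ADME assay on MSTO-211H cells (Homo sapiens) for inhibition, read by trypan blue exclusion, with a stated time of 72 h (on this read-out lower numbers stand for stronger inhibition of growth and higher numbers for weaker inhibition of growth), compound 1 gives 14800 nM, the highest of the two numbers shown. Its nearest neighbour is compound 2, which gives 8500 nM; the gap between these two numbers is within the usual scatter, so nothing can be said about which of the two compounds inhibits growth more strongly.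

The compound still to be measured is compound 3, `O=C(/C=C/c1ccccc1)c1cccc([N+](=O)[O-])c1`. Compared with compound 1 it carries a different group on the aromatic ring:
nitro in place of methoxy on an aromatic carbon
The change sits on an aromatic carbon of a six-membered aromatic ring of carbon only, meta to a large group.

Going by the values given here, no measured pair shows the effect of such an exchange here, so the expectation rests only on the two numbers above. Since the two measured variants of this ring lie within the scatter of each other, the step from compound 1 to compound 3 is expected to be small, at most near the edge of the scatter and in no firm direction: a 1.5-fold lower number from compound 1 to compound 3 (0.17 log units; within the scatter). In this assay compound 3 is therefore expected to give about 10000 nM, in a range from 4000 nM to 30000 nM.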

Compound 3, concentration for 50% growth inhibition: 10300 nM
Beside the measured number, compound 3's estimate is 1.0-fold (0.01 log units) below it; the range from low to high includes it.
By their numbers in this assay, from the lowest: compounds 2, 3 and 1 (each within the scatter of the next).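

Exchanging methoxy for nitro on an aromatic carbon, meta to a large group, gives a 1.4-fold lower number from compound 1 to compound 3 (0.16 log units; within the scatter) in this assay. This is the first pair shown that differs in one place only, so it gives a direct reading of this position that the earlier comparison could not supply. Although nitro has more heavy atoms and more hydrogen-bond acceptors than methoxy, and adds a double bond outside the aromatic rings, this read-out does not separate compound 1 from compound 3, so at this position the exchange has no measurable effect on growth inhibition in these cells; no other measurement bears on this result, and it offers no explanation for it.

As far as these compounds go, it remains open whether any group at this position can move the number beyond the scatter, and an amine, a carboxylic acid or a longer chain on the same aromatic carbon would put that to the test. From the compounds shown here alone, it is also open whether the same exchange of methoxy for nitro would stay as quiet on a different carbon of this ring.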